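The source may hold more compounds than are shown below. What is called first, only, known or untested is meant among the compounds shown, and "the series" means these compounds.

Working notes on the series. Four compounds sit on two related cores. Compound 1 `Cc1[nH]nc(N)c1-c1ccc(Cl)c(Cl)c1` carries two chloro groups on its aryl ring; compound 2 `Cc1[nH]nc(N)c1-c1cccc(Cl)c1` is its counterpart with one chloro removed. Compound 3 `CC(=O)n1nc(C)c(-c2ccc(Cl)c(Cl)c2)c1N` carries the same two chloro groups on a core bearing an acetyl group, and compound 4 `CC(=O)n1nc(C)c(-c2ccc(Cl)cc2)c1N`, not yet measured, is the matching compound with one chloro removed. The difference between the two cores is not broken down here.

In an assay on Sf9 cells for inhibition of mitogen-activated protein kinase kinase kinase 14 (Homo sapiens), read by ADP-Glo, with a stated time of 60 min (on this read-out lower numbers stand for stronger inhibition and higher numbers for weaker inhibition), compound 1 gives > 100000 nM, which is a limit of the assay and not a number. In this assay compound 2 gives > 100000 nM, again a limit. In this assay, within the data shown here, compound 3 gives 8400 nM, the only number in the set.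

The change from compound 1 to compound 2 is hydrogen in place of chloro on an aromatic carbon. Its step, a step that the two limits leave unreadable from compound 1 to compound 2, cannot be read because the limit of > 100000 nM in this assay, at which 2 of the 3 values shown sit, holds both ends. The change from compound 3 to compound 4 is hydrogen in place of chloro on an aromatic carbon. The surroundings differ: in compound 1 the carbon is para to a group of 7 heavy atoms, in compound 3 it is meta to a large group, so this is the same kind of change rather than the same change.

Among the measured compounds shown here, no measured step fixes the size of this change, so only the anchor of compound 3 at 8400 nM is available; the step from compound 3 to compound 4 is expected to be a 2.4-fold higher number from compound 3 to compound 4 (0.38 log units; beyond the scatter). Compound 4 is therefore estimated at 20000 nM, between 5000 nM and 100000 nM.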

Compound 4, half-maximal inhibitory concentration: > 100000 nM
Compound 4: a limit, no number; the forecaster's own chance of this, stated with the estimate: 30%; middle value at least 5.0-fold (0.69 log units) away from the limit.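

In this assay, hydrogen in place of chloro on the core bearing the acetyl group gives an at least 11-fold higher number from compound 3 to compound 4 (1.07 log units; beyond the scatter), so on this core the read-out of compound 3 depends on the chloro that is meta to a large group. Compound 4 gives > 100000 nM, which is a limit of the assay and not a number, so this step has a lower bound and no measured size. Whether the change carries over between the two cores stays unsettled, as the chloro that leaves in compound 1 stands at a different place from the one that leaves in compound 3, and the step from compound 1 to compound 2 cannot be read because both ends sit at the assay limit: the limit of > 100000 nM in this assay, at which 3 of the 4 values shown sit.

The compounds shown leave open whether a group other than chloro at this place, such as methyl, methoxy or an amine, would keep or change the read-out of compound 3. They also leave open how far the read-out on this core follows the acetyl group itself, since a longer acyl chain or a carboxylic acid in its place does not appear among them.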